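Aryl variation on the saturated ring carbon: compound 4

The compounds below may be only part of what the source reports. "The series", "measured", "known", "first", "only" and "open" are said of these compounds alone.

The shared core of compound 1 `N#CC1=C(N)OC(c2c[nH]c3ccccc23)=C(C#N)C1c1ccccc1` is carried through compound 2 `N#CC1=C(N)OC(c2c[nH]c3ccccc23)=C(C#N)C1c1ccccc1Cl` and compound 3 `CN(C)c1ccc(C2C(C#N)=C(N)OC(c3c[nH]c4ccccc34)=C2C#N)cc1`. In a functional assay, tested at 200 ug/mL (on this read-out lower numbers stand for a weaker effect and higher numbers for a stronger effect at the one concentration tested), compound 1 gives 24.5%, compound 2 gives 14.5% and compound 3 gives 20.5%. The number for compound 3 sits in the middle of the three as read, yet within the scatter of both others: a number 10 percentage points lower from compound 1 to compound 2 (within the scatter), a number 4 percentage points lower from compound 1 to compound 3 (within the scatter) and a number 6 percentage points higher from compound 2 to compound 3 (within the scatter). Compound 4 `N#CC1=C(N)OC(c2c[nH]c3ccccc23)=C(C#N)C1c1ccccc1F` differs from compound 3 at one place: 2-fluorophenyl in place of 4-(dimethylamino)phenyl on a saturated ring carbon. Among the measured compounds shown here, the steps that bear on it are a number 6 percentage points higher from compound 2 to compound 3 (within the scatter) and a number 10 percentage points lower from compound 1 to compound 2 (within the scatter), both within the scatter, so no step beyond the scatter is expected in this assay. Compound 4 is expected at 18%, within 8% to 28%. The expected step is a number 2.5 percentage points lower from compound 3 to compound 4 (within the scatter).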

Compound 4, a percentage reported as activity, at one concentration (the size of the read-out at that concentration, not a potency): "not active" (no number reported)
Compound 4 has no reported number here; there is nothing to compare the estimate with.
By their numbers in this assay, from the lowest: compounds 2, 3 and 1 (each within the scatter of the next).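

Among the compounds shown here, compound 4 is reported in this assay as "not active" with no number, so no step from compound 3 or any other compound can be read. The compounds shown leave open how 2-fluorophenyl compares with the other aryl groups on the saturated ring carbon. No evidence bears on this result.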